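This account rests on a few compounds, and the source may have more. Where it says the series, first, only, none or still open, it means among the compounds named here.

Measured so far:
Compound 1, `C[C@H]1C=C2C=C[C@H](C)[C@H](CCC3C[C@@H](O)CC(=O)O3)[C@H]2[C@@H](OCc2ccc(Cl)cc2)C1`, in an assay for inhibition of 3-hydroxy-3-methylglutaryl-coenzyme A reductase (Rattus norvegicus) (on this read-out higher numbers stand for weaker inhibition and lower numbers for stronger inhibition), gives 170 nM.
Compound 2, `C=CCO[C@H]1C[C@@H](C)C=C2C=C[C@H](C)[C@H](CCC3C[C@@H](O)CC(=O)O3)[C@H]21`, gives 370 nM.
Compound 3, `C=CCC(=O)O[C@H]1C[C@@H](C)C=C2C=C[C@H](C)[C@H](CCC3C[C@@H](O)CC(=O)O3)[C@H]21`, gives 2.9 nM.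

Compound 3 has the lowest number of the three, separated from the others by two large steps: a 59-fold lower number from compound 1 to compound 3 (1.77 log units; beyond the scatter) and a 130-fold lower number from compound 2 to compound 3 (2.11 log units; beyond the scatter). Compound 4, `C=C(C)CO[C@H]1C[C@@H](C)C=C2C=C[C@H](C)[C@H](CCC3C[C@@H](O)CC(=O)O3)[C@H]21`, differs from compound 3 by 2-methylprop-2-en-1-yl in place of allylcarbonyl on an oxygen on a saturated carbon. The step that bears on this is a 130-fold lower number from compound 2 to compound 3 (2.11 log units; beyond the scatter), where adding the carbonyl gave a large drop; compound 4 again has no carbonyl at that oxygen, like compound 2. Compound 4 is therefore expected to show a large rise, a 120-fold higher number from compound 3 to compound 4 (2.08 log units; beyond the scatter), back to the region of compound 2. The estimate for compound 4 is 350 nM, with a range from 120 nM to 1200 nM.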

Compound 4, half-maximal inhibitory concentration: 360 nM
Compound 4: middle estimate off by 1.0-fold (0.01 log units), on the low side, within the range that was stated.
By their numbers in this assay, from the lowest: compound 3; then compound 1; then compounds 4 and 2 (each within the scatter of the next).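

The step of a 1.0-fold lower number from compound 2 to compound 4 (0.01 log units; within the scatter), for methyl in place of hydrogen on a double-bonded chain carbon, shows that the allyl and 2-methylprop-2-en-1-yl groups on this oxygen cannot be told apart in this assay. The step of a 120-fold higher number from compound 3 to compound 4 (2.09 log units; beyond the scatter) means that two compounds without the carbonyl, not just one, now sit far from compound 3. The step of a 2.1-fold higher number from compound 1 to compound 4 (0.33 log units; beyond the scatter) shows that the gap to the 4-chlorobenzyl group stays modest.

Nothing given here explains these numbers. From the compounds shown here alone, whether an amide at this oxygen, or a longer chain on the carbonyl, would stay near compound 3 remains open.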